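From fluoro to trifluoromethyl on the amide-bearing ring

The compounds below may be only part of what the source reports. "The series", "measured", "known", "first", "only" and "open" are said of these compounds alone.

Compound 1 `O=C(Nc1ccccc1)c1ccc(-c2ncccc2C(F)(F)F)cc1` gives "not determined" (no result reported) in a functional assay for antagonist activity at transient receptor potential cation channel subfamily V member 1 (Rattus norvegicus) (on this read-out higher numbers stand for weaker inhibition and lower numbers for stronger inhibition), so no result is reported for it.
Compound 2 `N#Cc1ccc(NC(=O)c2ccc(-c3ncccc3C(F)(F)F)cc2)cc1` gives 1300 nM in this assay.
Compound 3 `Cc1cccnc1-c1ccc(C(=O)Nc2ccc(F)cc2)cc1` gives > 4000 nM in this assay, which is a limit of the assay and not a number.

Of the three compounds shown, only compound 2 has a single number. Compound 3 stands at the limit of > 4000 nM in this assay, at which 1 of the 3 values shown sits, so its inhibition is known only to be weaker than that boundary, and compound 1 adds no number at all. Among the measured compounds shown here, no step between two measured compounds is available, so nothing shows how large an effect a change on the ring that carries the amide nitrogen tends to have here.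

Compound 4 `Cc1cccnc1-c1ccc(C(=O)Nc2ccc(C(F)(F)F)cc2)cc1` differs from compound 3 in one place: trifluoromethyl in place of fluoro on an aromatic carbon. With compound 3 resting on a limit, the step is expected to stay close to that limit or move modestly toward stronger inhibition, with the size of the step in this assay from compound 3 to compound 4 expected to be around an at least 1.3-fold lower number from compound 3 to compound 4 (0.12 log units; that floor lies within the scatter). In this assay compound 4 is therefore expected to give roughly 3000 nM, with a plausible range from 800 nM to 12000 nM.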

Compound 4, half-maximal inhibitory concentration: 81 nM
Beside the measured number, compound 4's estimate is 37-fold (1.57 log units) above it, and the stated range ends above it.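

Trifluoromethyl in place of fluoro, on an aromatic carbon para to a large group, gives an at least 49-fold lower number from compound 3 to compound 4 (1.69 log units; beyond the scatter) in this assay. Among the compounds shown here, the earlier compounds offered no step at all, so this is the first sign that a single change at this position can move the read-out well beyond the usual scatter of repeated measurements. Compound 3 holds a limit of the assay and not a number, so the printed step is a floor and not an exact size: the limit of > 4000 nM in this assay, at which 1 of the 4 values shown sits.

With only one change shown at this position, it remains open whether the stronger inhibition follows from the larger group in general or from trifluoromethyl in particular, and groups such as chloro, methyl, methoxy or an amine at the same carbon would help to separate those two readings. Also open, as far as these compounds go, is whether the same swap from fluoro to trifluoromethyl would have a similar effect if the methyl group elsewhere on the core were replaced by trifluoromethyl, the group found at that place in compound 1 and compound 2.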